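The source may report more compounds than this note shows. Statements on the series, on what has been measured and on what is new or still open speak of the compounds shown alone.

Working notes on the series. Among the measured compounds shown here, the two measured members share one fused core. Compound 1 `N#CSc1c(-c2ccccc2)nc2sc(Cc3ccccc3)nn12` carries a thiocyanate and a phenyl group; compound 2 `O=Cc1c(-c2ccc([N+](=O)[O-])cc2)nc2sc(Cc3ccccc3)nn12` carries a formyl group and a nitrophenyl group. In a functional assay on cells (Cancer cell lines, Homo sapiens) for inhibition (a higher number here means a weaker inhibitor of growth, a lower number a stronger inhibitor of growth), compound 1 gives 77600 nM. In this assay compound 2 gives 26900 nM, which is the lower of the two numbers, and the gap to compound 1 lies beyond the scatter. Compound 1 and compound 2 differ at two places. No single-point step can be read from them.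

The unmeasured compound 3 `O=[N+]([O-])c1ccc(-c2nc3sc(Cc4ccccc4)nn3c2Br)cc1` keeps the nitrophenyl group of compound 2 and differs only in bromo in place of formyl on an aromatic carbon. For the measured compounds named here, no step between measured compounds covers this exchange, so the expectation rests on compound 2 alone. The expected step from compound 2 to compound 3 in this assay is small, without a clear direction, a 1.1-fold lower number from compound 2 to compound 3 (0.03 log units; within the scatter), likely within or just beyond the scatter. The estimate for compound 3 in this assay is 25000 nM, with a range from 8000 nM to 80000 nM.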

Compound 3, concentration for total growth inhibition: 47900 nM
For compound 3 the middle estimate is 1.9-fold (0.28 log units) below the measured one, within the range that was stated.
By their numbers in this assay, from the lowest: compounds 2, 3 and 1 (each within the scatter of the next, the first and the last beyond it).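

Among the compounds shown here, the exchange gives the first single-place step: in this assay the move from formyl to bromo on this aromatic carbon is a 1.8-fold higher number from compound 2 to compound 3 (0.25 log units; within the scatter). With the nitrophenyl group and the rest of compound 2 held fixed, the two groups cannot be told apart at this position, even though formyl brings a double bond outside aromatic rings and a hydrogen-bond acceptor and bromo brings neither. No supporting measurement bears on the reason for this result.

Compound 1 differs from compound 2 and from compound 3 at two places, so neither its thiocyanate nor its unsubstituted phenyl group can be read as a separate step. Going by these compounds, whether an amine, a carboxylic acid or a longer chain at this position would stay within the scatter of bromo and formyl remains open, as does whether the match between bromo and formyl would hold with phenyl in place of nitrophenyl.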